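The source may report more compounds than this note shows. Statements on the series, on what has been measured and on what is new or still open speak of the compounds shown alone.

Compound 1 `C=C[C@@](C)(/C=C/c1ccc(OCc2ccccc2)cc1)CCC=C(C)C` stands in a functional assay on HepG2 cells (Homo sapiens) for cytotoxicity, with a stated time of 72 h (a lower number here means that less compound is needed, a higher number that more compound is needed for the effect), only at a limit: compound 1 gives > 52000 nM, a bound of the measurement rather than a number. Compound 2 `C=C[C@@](C)(/C=C/c1ccc(Nc2cc(F)c(F)cc2F)cc1)CCC=C(C)C` likewise reaches only a limit, giving > 52000 nM in this assay. Both values sit at the limit of > 52000 nM in this assay, at which 2 of the 2 values shown sit. Among the compounds with values here, no step between measured compounds is available. Compound 3 `C=C[C@@](C)(/C=C/c1ccc(-c2ccccc2)cc1)CCC=C(C)C` differs from compound 1 by phenyl in place of benzyloxy on an aromatic carbon. Both measured values being limits, no direction can be read from them. The expected step is a step that the limit leaves unreadable from compound 1 to compound 3, none beyond the scatter. Compound 3 is expected at 60000 nM, within a range of 15000 nM to 200000 nM, most likely again reported as a limit.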

Compound 3, half-maximal effective concentration: > 52000 nM
Compound 3 gave a limit, no number; the forecaster's own chance of this, stated with the estimate: 75%; the middle value lies beyond the limit too.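

Compound 1 and compound 3 both give limits rather than numbers, so no step between them can be read: the limit of > 52000 nM in this assay, at which 3 of the 3 values shown sit.

The compounds shown leave open whether any group on this aromatic carbon gives a measurable value in this assay.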